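The source may hold more compounds than are shown below. What is called first, only, known or untested is meant among the compounds shown, and "the series" means these compounds.

For the measured compounds named here, compound 2 `Cc1nc(S(C)(=O)=O)ccc1Oc1ncnc(OC2CCN(C(=O)OC3(C(F)(F)F)CCC3)CC2)c1F` stands at the largest of the three numbers so far in a functional assay on isolated protein for inhibition of Glucose-dependent insulinotropic receptor (Homo sapiens), read by HTRF and cAMP accumulation (on this read-out higher numbers stand for an effect only at larger amounts of compound and lower numbers for an effect already at smaller amounts), giving 14.3 nM; its separation from compound 3 is only a 1.1-fold lower number from compound 2 to compound 3 (0.03 log units; within the scatter). Compound 1 `Cc1nc(S(C)(=O)=O)ccc1Oc1ncnc(OC2CCN(C(=O)OC(C)(C)C(F)(F)F)CC2)c1F` gives 6.53 nM in this assay, and compound 3 `Cc1nc(S(C)(=O)=O)ccc1Oc1ncnc(OC2CCN(C(=O)SC3(C)CC3)CC2)c1F` gives 13.2 nM in this assay. Compound 4 `Cc1nc(S(C)(=O)=O)ccc1Oc1ncnc(OC2CCN(C(=O)c3nc(C(C)(C)F)no3)CC2)c1F` has not yet been measured in this assay. It differs from compound 2 by a group of 9 heavy atoms (5 carbon, 2 nitrogen, 1 oxygen, 1 fluorine; one five-membered aromatic ring with 3 hetero atoms) in place of a group of 9 heavy atoms (5 carbon, 1 oxygen, 3 fluorine; one four-membered non-aromatic ring of carbon only), on a carbonyl carbon. Going by the values given here, the steps that bear on this change are those that also alter the group on the carbonyl carbon: a 2.2-fold higher number from compound 1 to compound 2 (0.34 log units; beyond the scatter) and a 2.0-fold higher number from compound 1 to compound 3 (0.31 log units; beyond the scatter), both modest, and a 1.1-fold lower number from compound 2 to compound 3 (0.03 log units; within the scatter), which lies within the scatter. Three different groups on the carbonyl carbon thus gave numbers spread over only a narrow span, so a step of no more than modest size is expected here, with no clear direction. The expected step is a 1.2-fold lower number from compound 2 to compound 4 (0.08 log units; within the scatter). For compound 4 the estimated value in this assay is 12 nM, with a range from 4 nM to 40 nM.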

Compound 4, half-maximal effective concentration: 43.4 nM
The estimate for compound 4 lay 3.6-fold (0.56 log units) below the measured number, outside the stated range (above it).
By their numbers in this assay, from the lowest: compound 1; then compounds 3 and 2 (each within the scatter of the next); then compound 4.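

In this assay the five-membered aromatic ring with 3 hetero atoms on the carbonyl carbon sets compound 4 apart from all three earlier compounds: there is a 3.0-fold higher number from compound 2 to compound 4 (0.48 log units; beyond the scatter) and a 3.3-fold higher number from compound 3 to compound 4 (0.52 log units; beyond the scatter) and also a 6.6-fold higher number from compound 1 to compound 4 (0.82 log units; beyond the scatter) on the same scale. The earlier groups, joined to the carbonyl carbon through oxygen or sulfur, stayed within a modest span, but this position is clearly not indifferent to what sits there: compound 4 has the highest number of the four, so it needs the most compound for its effect. Nothing measured here explains the shift. Going by these compounds, compound 4 changes the ring and the atom bound to the carbonyl carbon together, and which of these matters stays open. Also open, on these data alone, is whether a phenyl ring or a plain amine on this carbonyl carbon would stand nearer compound 1 or compound 4.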